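Aryl Substituent Change on a Lactone Side Chain

The source may report more compounds than this note shows. Statements on the series, on what has been measured and on what is new or still open speak of the compounds shown alone.

Compound 1 `C=C1CC[C@@H]2[C@](C)(COC(=O)c3cccnc3)[C@H](OC(=O)c3cccnc3)CC[C@@]2(C)[C@@H]1/C=C/C1=C/C(=C\C(C)=C\CCC/C=C/C)OC1=O`: 28000 nM
Compound 2 `C=C1CC[C@@H]2[C@](C)(COC(=O)c3cccnc3)[C@H](OC(=O)c3cccnc3)CC[C@@]2(C)[C@@H]1/C=C/C1=C/C(=C\c2ccc(Cl)cc2)OC1=O`: 6000 nM

Of the compounds shown here, two have been measured in an assay on isolated protein for inhibition of Maltase-glucoamylase (Homo sapiens); a higher number here means a weaker inhibitor, a lower number a stronger inhibitor. Compound 1 gives 28000 nM, and compound 2 gives 6000 nM. Compound 2 thus holds the lowest number of the two; its nearest neighbour is compound 1, and the step of a 4.7-fold lower number from compound 1 to compound 2 (0.67 log units; beyond the scatter) lies beyond the scatter. That step exchanges a chain for a chlorophenyl group on the double-bonded chain carbon bound to the ring carbon of the lactone.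

Compound 3 `C=C1CC[C@@H]2[C@](C)(COC(=O)c3cccnc3)[C@H](OC(=O)c3cccnc3)CC[C@@]2(C)[C@@H]1/C=C/C1=C/C(=C\c2ccc(N(C)C)cc2)OC1=O` has not yet been measured. It differs from compound 2 only in the change (dimethylamino in place of chloro on an aromatic carbon), which is dimethylamino in place of chloro on an aromatic carbon. Among the measured compounds shown here, no measured step touches that aromatic carbon: the only known step, a 4.7-fold lower number from compound 1 to compound 2 (0.67 log units; beyond the scatter), installs the whole ring rather than altering a group on it, so it offers no direct guide. With nothing to point either way, no step beyond the scatter is expected in this assay, and the expected step of a 1.1-fold lower number from compound 2 to compound 3 (0.04 log units; within the scatter) is small. Compound 3 is therefore estimated at 5500 nM, within a range from 1500 nM to 20000 nM.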

Compound 3, half-maximal inhibitory concentration: 25000 nM
Beside the measured number, compound 3's estimate is 4.5-fold (0.66 log units) below it, outside the stated range (above it).
By their numbers in this assay, from the lowest: compound 2; then compounds 3 and 1 (each within the scatter of the next).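

In this assay the group on the aromatic carbon proves to count: swapping chloro for dimethylamino gives a 4.2-fold higher number from compound 2 to compound 3 (0.62 log units; beyond the scatter) and so takes away about as much as the earlier exchange of the chain for the 4-chlorophenyl group gave, which was a 4.7-fold lower number from compound 1 to compound 2 (0.67 log units; beyond the scatter) in that assay. The aromatic ring alone therefore does not carry the lower number, for with dimethylamino on it the step is a 1.1-fold lower number from compound 1 to compound 3 (0.05 log units; within the scatter) and the compound with the ring does not separate from the one with the chain. Nothing measured here explains why chloro and dimethylamino differ at this place.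

With only two groups on this ring, the compounds shown leave open whether chloro lowers the number or dimethylamino raises it, and a plain phenyl ring with hydrogen on that carbon would be the reference that separates the two readings. They also leave open how other groups at the same place, such as fluoro, bromo, methoxy or nitrile, would rank against compound 2 in this assay on this same core.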